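This account rests on a few compounds, and the source may have more. Where it says the series, first, only, none or still open, it means among the compounds named here.

Measured in a functional assay on HCT-116 cells (Homo sapiens) for cytotoxicity, read by MTT assay, with a stated time of 72 h; a lower number here means a stronger inhibitor, a higher number a weaker inhibitor:

- Compound 1 `Nc1ccccc1NC(=O)c1ccc(NC(=S)NCc2ccccc2F)cc1`: 6300 nM
- Compound 2 `Nc1ccccc1NC(=O)c1ccc(NC(=S)NCc2cccc(Cl)c2)cc1`: 5900 nM

Compound 2 gives 5900 nM, and compound 1 gives 6300 nM. These two values lie within the scatter of each other, so neither compound can be ranked above the other.

Compound 3 `Nc1ccccc1NC(=O)c1ccc(NC(=S)NCc2cncc(Br)c2)cc1` keeps the shared core and differs from compound 2 as follows: 5-bromopyridin-3-yl in place of 3-chlorophenyl on a saturated chain carbon bound to an amide-type nitrogen. The new group, 5-bromopyridin-3-yl, stands in place of 3-chlorophenyl on a saturated chain carbon bound to an amide-type nitrogen.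

Among the compounds with values here, only one measured step bears on this change. It is a 1.1-fold lower number from compound 1 to compound 2 (0.03 log units; within the scatter), an exchange at the same place that stays within the scatter. Neither measured compound has a hetero atom in this ring, so the evidence is thin, and no shift beyond the scatter is expected in this assay.

The expected step is a 1.0-fold higher number from compound 2 to compound 3 (0.01 log units; within the scatter). For compound 3 the estimated value is 6000 nM, with an expected range of 2500 nM to 14000 nM.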

Compound 3, half-maximal inhibitory concentration: 9200 nM
Compound 3: the middle estimate sits 1.5-fold (0.19 log units) below what was measured; the measured number falls inside the stated range.
By their numbers in this assay, from the lowest: compounds 2, 1 and 3 (each within the scatter of the next).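

A ring with a hetero atom, 5-bromopyridin-3-yl, on the saturated chain carbon bound to an amide-type nitrogen, does not separate from either carbon-only ring in this assay: the exchange for 3-chlorophenyl gives a 1.6-fold higher number from compound 2 to compound 3 (0.19 log units; within the scatter), and the exchange for 2-fluorophenyl gives a 1.5-fold higher number from compound 1 to compound 3 (0.16 log units; within the scatter). The three compounds therefore cannot be ranked, and across these rings this position shows no shift beyond the scatter, now including a ring nitrogen and a bromine in place of an all-carbon halogenated ring. No supporting measurement bears on what lies behind this result.

As far as these compounds go, it remains open whether the unsubstituted pyridin-3-yl ring would read any differently from the brominated one. From the compounds shown here alone, it is also open whether a longer chain before the ring, or a carboxylic acid on it, would move the number beyond the scatter.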